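The compounds below may be only part of what the source reports. "The series", "measured", "known", "first", "only" and "open" are said of these compounds alone.

Working notes on a small urea series around a shared core.

Three members have been run in a functional assay on PC-9 cells (Homo sapiens) for antiproliferative activity, read by MTT assay, with a stated time of 48 h; a higher number here means a weaker inhibitor, a lower number a stronger inhibitor. Compound 1 `COc1ccc(OC)c(Nc2cc(NC(=O)Nc3c(Cl)cccc3Cl)ncn2)c1` gives 1340 nM. Compound 2 `COc1cc(Nc2cc(NC(=O)Nc3c(Cl)cccc3Cl)ncn2)cc(OC)c1` gives 3180 nM. Compound 3 `COc1cc(NC(=O)Nc2cc(Nc3cc(I)ccc3OC)ncn2)cc(OC)c1` gives 3540 nM. Compound 3 thus holds the highest number of the three, though its gap to compound 2 lies within the scatter of repeated measurements and only the gap to compound 1 lies beyond it. All three sit in the same broad region of weak activity.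

Compound 4 `COc1cc(NC(=O)Nc2cc(Nc3cc(C(F)(F)F)ccc3OC)ncn2)cc(OC)c1` is the next member to be tested. Relative to compound 3 the change is trifluoromethyl in place of iodo on an aromatic carbon; the rest of the structure is kept.

Going by the values given here, no pair of measured compounds differs by a single change, so the size of this step has no direct precedent here. The step from compound 3 to compound 4 is expected to be small, a 1.2-fold lower number from compound 3 to compound 4 (0.07 log units; within the scatter), without a clear direction beyond the scatter, since the three measured values cluster closely. Compound 4 is therefore estimated at 3000 nM in this assay, with a plausible range from 1000 nM to 9000 nM.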

Compound 4, half-maximal inhibitory concentration: 6220 nM
Beside the measured number, compound 4's estimate is 2.1-fold (0.32 log units) below it, within the range that was stated.
By their numbers in this assay, from the lowest: compound 1; then compounds 2, 3 and 4 (each within the scatter of the next).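

In this assay, the series now has its first single-place step, a 1.8-fold higher number from compound 3 to compound 4 (0.24 log units; within the scatter), with trifluoromethyl in place of iodo on the aromatic carbon para to a methoxy group. At this position, the exchange of a single iodine atom for a group of 4 heavy atoms therefore leaves the two compounds inside the usual scatter, so this carbon accepts either group without a readable separation in this assay. No measured evidence bears on this step.

On these data alone, whether an amine, a carboxylic acid or a longer chain such as n-butyl on the same carbon would give a step beyond the scatter remains open. Also open, as far as these compounds go, is whether the iodo to trifluoromethyl exchange would give a similar step on the urea side carried by compound 1.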